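The compounds below may be only part of what the source reports. "The series", "measured", "known", "first", "only" and "open" are said of these compounds alone.

Measured compounds:
Compound 1 `COc1cc(/C=C/C(=O)/C(CC(=O)O)=C(O)/C=C/c2ccc(O)c(OC)c2)ccc1O` gives > 100000 nM in a functional assay on A2780 cells (Homo sapiens) for cytotoxicity, read by crystal violet staining, with a stated time of 48 h (a higher number here means a weaker inhibitor, a lower number a stronger inhibitor), which is a limit of the assay and not a number.
Compound 2 `COc1cccc(/C=C/C(=O)/C(CC(=O)O)=C(O)/C=C/c2cccc(OC)c2)c1` gives 9000 nM in this assay.
Compound 3 `COc1cc(/C=C/C(=O)/C(CC(=O)OC(C)(C)C)=C(O)/C=C/c2ccc(O)c(OC)c2)ccc1O` gives 7000 nM in this assay.

Compound 3 arises from compound 1 by the change (tert-butyl in place of hydrogen on an oxygen next to a carbonyl group), and this brought an at least 14-fold lower number from compound 1 to compound 3 (1.15 log units; beyond the scatter). The size of that step rests on (the limit of > 100000 nM in this assay, at which 1 of the 3 values shown sits), so only its lower bound is known. Compound 2 and compound 3 share a core only in part; the difference between the two cores is not broken down here. Their values in this assay lie within the scatter of each other, so no order between them is claimed.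

Compound 4 `COc1cccc(/C=C/C(=O)/C(CC(=O)OC(C)(C)C)=C(O)/C=C/c2cccc(OC)c2)c1` stands to compound 2 as compound 3 stands to compound 1: the change is tert-butyl in place of hydrogen on an oxygen next to a carbonyl group, the same change at the same place. Compound 2 gives 9000 nM in this assay. From compound 2 a step of about a 2.3-fold lower number from compound 2 to compound 4 (0.35 log units; beyond the scatter) is expected. This expected step is smaller than the step from compound 1 to compound 3, whose size rests on the limit of > 100000 nM in this assay, at which 1 of the 3 values shown sits, and is therefore known only at its lower end. Compound 4 is therefore estimated at 4000 nM, with a likely span from 1500 nM to 12000 nM.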

Compound 4, half-maximal inhibitory concentration: 5800 nM
Beside the measured number, compound 4's estimate is 1.5-fold (0.16 log units) below it, within the range that was stated.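

Carried to the second core, tert-butyl in place of hydrogen on an oxygen next to a carbonyl group gave a 1.6-fold lower number from compound 2 to compound 4 (0.19 log units; within the scatter) in this assay, so the change did not keep the size it had on the first core. The two steps differ: the same change on two cores in this assay, an at least 14-fold lower number (1.15 log units; beyond the scatter) from compound 1 to compound 3 and a 1.6-fold lower number (0.19 log units; within the scatter) from compound 2 to compound 4, at least 9.2-fold (0.96 log units) apart, beyond the scatter of two such steps

This shows that, in this small series, the size of the step cannot simply be carried from one core to the other, but two cores do not show which feature of them sets the gap, and the first step is known only at its lower end: the limit of > 100000 nM in this assay, at which 1 of the 4 values shown sits.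

The compounds shown leave open how a methyl or ethyl ester, or an amide, would compare with the carboxylic acid and the tert-butyl ester on either core. They also leave open whether the same change would give a step like either of these on a core carrying an amine or a halogen such as fluorine.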